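Amide aryl replacement on the shared core

A few compounds are considered here, and "the series" means these few. Any claim that something is new, unique, unknown or untested is made for them only; others in the source may bear on it.

Compound 1 `COc1ccc2c(=O)c(/C=C/C(=O)Nc3cccc(Cl)c3)coc2c1` is the weakest point of reference on the numbers shown, and its value is only a limit. In a functional assay (QGY7701 cells, Homo sapiens) for inhibition, read by MTT assay, with a stated time of 48 h (a lower number here means a stronger inhibitor, a higher number a weaker inhibitor), compound 1 gives > 100000 nM, which is a limit of the assay and not a number (the limit of > 100000 nM in this assay, at which 1 of the 3 values shown sits). Compound 2 `COc1ccc2c(=O)c(/C=C/C(=O)Nc3ccccc3)coc2c1` gives 14000 nM in this assay, and compound 3 `COc1ccc2c(=O)c(/C=C/C(=O)NCc3ccc(F)cc3)coc2c1` gives 7960 nM. The step of an at least 7.1-fold lower number from compound 1 to compound 2 (0.85 log units; beyond the scatter) and the step of an at least 12-fold lower number from compound 1 to compound 3 (1.09 log units; beyond the scatter) both move away from the 3-chlorophenyl of compound 1 toward lower numbers, while the step of a 1.8-fold lower number from compound 2 to compound 3 (0.25 log units; within the scatter) does not separate phenyl from 4-fluorobenzyl.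

Compound 4 `CCOc1ccc(NC(=O)/C=C/c2coc3cc(OC)ccc3c2=O)cc1` is not yet measured in this assay. It differs from compound 1 in one place: 4-ethoxyphenyl in place of 3-chlorophenyl on an amide-type nitrogen. Both measured steps that leave the 3-chlorophenyl bear on this change, and both were at least modest to large, so a lower number is expected for compound 4 in this assay, though its size is uncertain. Compound 4 is expected near 20000 nM, within 5000 nM to 100000 nM. That estimate means an expected step of an at least 5.0-fold lower number from compound 1 to compound 4 (0.69 log units; beyond the scatter).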

Compound 4, half-maximal inhibitory concentration: > 100000 nM
Compound 4: only a limit was reported; the forecaster's own chance of this, stated with the estimate: 30%; middle value at least 5.0-fold (0.69 log units) away from the limit.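

The opening reasoning treated leaving the 3-chlorophenyl as enough to lower the number, but in this assay compound 4 also gives only a limit of the assay, so the step from compound 1 cannot be read. What matters at this amide-type nitrogen is the group that enters, not just the loss of 3-chlorophenyl: ethoxy in place of hydrogen on an aromatic carbon gives an at least 7.1-fold higher number from compound 2 to compound 4 (0.85 log units; beyond the scatter), and 4-ethoxyphenyl in place of 4-fluorobenzyl gives an at least 12-fold higher number from compound 3 to compound 4 (1.09 log units; beyond the scatter). Among the compounds shown, the two substituted phenyl amides, compound 1 and compound 4, share one limit: the limit of > 100000 nM in this assay, at which 2 of the 4 values shown sit.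

The two limits leave chloro and ethoxy unranked, and the change of group cannot be separated from its place on the ring. From the compounds shown here alone, whether an amine on the phenyl, or a 2-phenylethyl on the amide-type nitrogen, gives a readable number remains open.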